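The source may report more compounds than this note shows. Statements on the series, on what has been measured and on what is new or still open speak of the compounds shown alone.

Compound 1 `Cc1nc(N)sc1CCCN/C(N)=N/C(=O)N[C@H](C)c1ccccc1` gives 7.59 nM in a functional assay on Right cardiac atrium for agonist activity at histamine H2 receptor (Cavia porcellus), with a stated time of 30 min, in the presence of a further agent that is not named here; a lower number here means that less compound is needed, a higher number that more compound is needed for the effect. Among the compounds with values here, that is the lower of the two numbers measured so far, but compound 2 `Cc1nc(N)sc1CCCN/C(N)=N/C(=O)NC(C)c1ccccc1F` gives 12.3 nM in this assay, and the two values lie within the scatter of each other, so no order between them can be claimed. Compound 3 `CCCCCCNC(=O)/N=C(\N)NCCCc1sc(N)nc1C` has not yet been measured in this assay. It differs from compound 1 in one place: hexyl in place of 1-phenylethyl on an amide-type nitrogen. Within the data shown here, no step between measured compounds speaks to this change; compound 1 and compound 2 both carry a ring on the amide-type nitrogen, so the direction can only be guessed. A modest loss is expected, the step from compound 1 to compound 3 being estimated at a 2.6-fold higher number from compound 1 to compound 3 (0.42 log units; beyond the scatter), a change that may not rise clearly beyond the scatter. Compound 3 is therefore expected to give 20 nM in this assay, within a range from 5 nM to 80 nM.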

Compound 3, half-maximal effective concentration: 15.9 nM
Compound 3: middle estimate off by 1.3-fold (0.10 log units), on the high side, within the range that was stated.
By their numbers in this assay, from the lowest: compounds 1, 2 and 3 (each within the scatter of the next, the first and the last beyond it).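

In this assay the amide-type nitrogen keeps a low nanomolar value without any ring on it: compound 3 gives 15.9 nM and the change of 1-phenylethyl to hexyl costs only a 2.1-fold higher number from compound 1 to compound 3 (0.32 log units; beyond the scatter) in a step that is modest, though beyond the scatter. The earlier compounds shown here both carried a ring at this place, so they could not show that an open hexyl chain is accepted there at so small a cost. Nothing measured here accounts for the size of this step.

The change removes the ring and the defined stereocentre together, so this one pair cannot separate what each contributes. As far as these compounds go, it also remains open how a shorter butyl chain, a longer octyl chain or a hexyl chain carrying an amine would compare with hexyl at this place.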